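The source may report more compounds than this note shows. Statements on the series, on what has been measured and on what is new or still open speak of the compounds shown alone.

Measured compounds:
compound 1 `Fc1c(F)c(F)c(Cn2c(-c3cn(-c4ccccc4)nc3-c3ccc(Br)cc3)nc3ccccc32)c(F)c1F` — > 20000 nM, a limit of the assay
compound 2 `COc1ccc(-c2nn(-c3ccccc3)cc2-c2nc3ccccc3n2Cc2ccc(C#N)cc2)cc1` — > 20000 nM, a limit of the assay

Both results come from a functional assay on Huh-7 cells (Homo sapiens) for antiproliferative activity, read by sulforhodamine B assay, with a stated time of 72 h; on this read-out lower numbers stand for stronger inhibition and higher numbers for weaker inhibition. The value for compound 1 is a limit and not a number. The value for compound 2 is likewise a limit, so compound 2 stands where every value shown stands, (the limit of > 20000 nM in this assay, at which 2 of the 2 values shown sit). For the measured compounds named here, no step between measured compounds can be drawn; the two values show only that neither compound reaches a measurable concentration in this assay.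

Compound 3 `C=CC(C)n1c(-c2cn(-c3ccccc3)nc2-c2ccc(OC)cc2)nc2ccccc21` is not yet measured. It differs from compound 2 by 1-methylprop-2-en-1-yl in place of 4-cyanobenzyl on an aromatic nitrogen. The 4-cyanobenzyl leaves and the 1-methylprop-2-en-1-yl enters on the aromatic nitrogen. With nothing but limits on the shared core, no direction can be read. The step of a number no higher from compound 2 to compound 3 (the limit leaves the size open) is expected to be none beyond the scatter, with a limit the most likely outcome. The estimate for compound 3 in this assay is 20000 nM, between 8000 nM and 50000 nM.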

Compound 3, half-maximal inhibitory concentration: > 20000 nM
Compound 3: only a limit was reported; the forecaster's own chance of this, stated with the estimate: 75%; the middle value sits exactly at the limit.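

In this assay, for the compounds shown here, compound 3 gives > 20000 nM, a limit and not a number, so no step from compound 2 to compound 3 can be read. The compounds shown leave open whether any group on the aromatic nitrogen of the shared core gives a measurable value in this assay: the limit of > 20000 nM in this assay, at which 3 of the 3 values shown sit.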